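A few compounds are considered here, and "the series" means these few. Any claim that something is new, unique, unknown or untested is made for them only; others in the source may bear on it.

Measured compounds:
Compound 1, `C[C@H](Oc1ccc2ncc(/C=C/c3nn[nH]n3)c(C(F)F)c2c1)c1c(Cl)cccc1Cl`, gives 3.3.
Compound 2, `C[C@H](Oc1ccc2ncc(/C=C/C(=O)O)c(C(F)F)c2c1)c1c(Cl)ccc(F)c1Cl`, gives 3.1.
Compound 3, `C[C@H](Oc1ccc2ncc(/C=C/c3nn[nH]n3)c(C3CC3)c2c1)c1c(Cl)cccc1Cl`, gives 4.3.

All three were measured in a physicochemical assay for lipophilicity, using the shake flask method; a lower number here means a more polar compound, a higher number a more lipophilic compound. Compound 1 and compound 3 share one core and differ in a single place: cyclopropyl in place of difluoromethyl on an aromatic carbon. That change produced a number 1.00 log units higher from compound 1 to compound 3 (beyond the scatter). Compound 2 rests on a different core; how its core differs from that of compound 1 is not broken down here. Its value and that of compound 1 lie within the scatter of each other, while compound 3 stands beyond the scatter from both.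

Compound 4, `C[C@H](Oc1ccc2ncc(/C=C/C(=O)O)c(C3CC3)c2c1)c1c(Cl)ccc(F)c1Cl`, has not yet been measured in this assay. It arises from compound 2 by the same kind of change: cyclopropyl in place of difluoromethyl on an aromatic carbon. The surroundings are not identical, since in compound 1 and compound 3 the group sits ortho to a 2-(2H-tetrazol-5-yl)ethenyl group, whereas in compound 2 and compound 4 it sits ortho to a 2-carboxyethenyl group. The expected step is a number 1.00 log units higher from compound 2 to compound 4 (beyond the scatter), which rests on the single earlier case where the same kind of change gave a number 1.00 log units higher from compound 1 to compound 3 (beyond the scatter). Compound 4 is therefore estimated at 4.1, most likely between 3.6 and 4.6.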

Compound 4, distribution coefficient: 4.1
Compound 4: the middle estimate sits on the measured number at the digits printed; the range from low to high includes it.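

In this assay the change from difluoromethyl to cyclopropyl gave a number 1.00 log units higher from compound 2 to compound 4 (beyond the scatter) and, on the other core, a number 1.00 log units higher from compound 1 to compound 3 (beyond the scatter), so in these two pairs the step carried over at the same size, ortho to a 2-carboxyethenyl group as well as ortho to a 2-(2H-tetrazol-5-yl)ethenyl group. Two pairs are only two cases, however, and they do not show that the step would keep this size on any further core. No measurement shown here gives a cause for the size of the step.

The compounds shown leave open whether the step would hold with another group in place of the 2-carboxyethenyl group, such as an amine or a longer carbon chain. Groups other than difluoromethyl and cyclopropyl at this ring carbon, such as methyl or trifluoromethyl, also lie outside these compounds, and how they would read in this assay remains an open question.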